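Morpholin-4-yl to Dimethylamino on a Sulfonyl Group

The compounds below may be only part of what the source reports. "The series", "measured", "known", "first", "only" and "open" are said of these compounds alone.

Three compounds built on one shared core, compound 1 `CCOC(=O)[C@@H]1CCCN(S(=O)(=O)c2ccc(S(=O)(=O)N3CCOCC3)cc2)C1`, compound 2 `CCN(CC)C(=O)[C@@H]1CCCN(S(=O)(=O)c2ccc(S(=O)(=O)N(CC)CC)cc2)C1` and compound 3 `CC(C)c1noc(N2CCN(C(=O)[C@@H]3CCCN(S(=O)(=O)c4ccc(S(=O)(=O)C(C)C)cc4)C3)CC2)n1`, were tested in a functional assay on MIA PaCa-2 cells (Homo sapiens) for inhibition, read by MTT assay, with a stated time of 3 days; a higher number here means a weaker inhibitor, a lower number a stronger inhibitor. In this assay compound 1 gives only a limit, reported as > 10000 nM. Compound 2 likewise gives a limit, > 10000 nM. Compound 3 also gives a limit, > 10000 nM. Going by the values given here, all three results sit at the limit of > 10000 nM in this assay, at which 3 of the 3 values shown sit, so no measured step between any two of them can be stated, and nothing separates compound 1 from the others.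

The next compound, compound 4 `CCOC(=O)[C@@H]1CCCN(S(=O)(=O)c2ccc(S(=O)(=O)N(C)C)cc2)C1`, differs from compound 1 in a single place: dimethylamino in place of morpholin-4-yl on a sulfonyl sulfur. The change removes one ring and leaves the rest of the molecule untouched. Among the compounds with values here, because every result so far rests at the limit of > 10000 nM in this assay, at which 3 of the 3 values shown sit, there is no measured step of any size to lean on when judging this change, and the most that can be said is that nothing yet points toward a gain.

Compound 4 is therefore expected to remain at the same limit, with an estimated 20000 nM and a range from 8000 nM to 60000 nM. The step this estimate implies, a step that the limit leaves unreadable from compound 1 to compound 4, is expected to be none beyond the usual scatter.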

Compound 4, half-maximal inhibitory concentration: > 10000 nM
Compound 4: a limit, no number (the forecaster's own chance of this, stated with the estimate: 85%); the middle value lies beyond the limit too.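

No step can be read between compound 1 and compound 4, because both results are limits and not numbers: the limit of > 10000 nM in this assay, at which 4 of the 4 values shown sit.

The compounds shown leave open which change to the shared core, if any, would bring a result in this assay that is an actual number, and so a first step that can be sized.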